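The source may hold more compounds than are shown below. What is called first, only, known or untested is meant among the compounds shown, and "the series" means these compounds.

Measured compounds: compound 1 `O=C(O)c1ccccc1-c1ccc(CCc2ncc(CC3CCCCC3)[nH]2)cc1`, compound 2 `COc1ccc(Cc2cnc(CCc3ccc(-c4ccccc4C(=O)O)cc3)[nH]2)cc1`, compound 3 `CCCCc1cnc(C(Cc2ccc(-c3ccccc3C(=O)O)cc2)C(C)C)[nH]1`.

In an in vitro functional assay on cells for agonist activity at Bombesin receptor subtype-3 (Homo sapiens), read by luminescence and calcium flux (on this read-out lower numbers stand for an effect already at smaller amounts and higher numbers for an effect only at larger amounts of compound), compound 1 gives 41 nM, compound 2 gives 5360 nM, and compound 3 gives 4620 nM. Compound 3 thus stands second highest of the three numbers, near compound 2 and far from compound 1.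

Compound 4 `CCCCc1cnc(CCc2ccc(-c3ccccc3C(=O)O)cc2)[nH]1` is the next compound to be measured. It differs from compound 3 by hydrogen in place of isopropyl on a saturated chain carbon bound to an aromatic carbon and a saturated chain carbon. Among the measured compounds shown here, the only step measured so far, a 130-fold higher number from compound 1 to compound 2 (2.12 log units; beyond the scatter), concerns a different site and a different kind of exchange, so it gives no direct guide to the removal of the isopropyl group. Compound 1, which also carries an unbranched chain between the core and the aromatic ring, shows a much lower number than compound 3, but compound 1 and compound 3 differ at the imidazole substituent as well, so that comparison is not clean.

On that basis the step from compound 3 to compound 4 is expected to be modest and downward, a 3.1-fold lower number from compound 3 to compound 4 (0.49 log units; beyond the scatter), with wide uncertainty. Compound 4 is therefore estimated at 1500 nM in this assay, with a range from 300 nM to 8000 nM.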

Compound 4, half-maximal effective concentration: 2710 nM
Compound 4: middle estimate off by 1.8-fold (0.26 log units), on the low side; the measured number falls inside the stated range.
By their numbers in this assay, from the lowest: compound 1; then compounds 4, 3 and 2 (each within the scatter of the next).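

In this assay, the exchange at the saturated chain carbon bound to an aromatic carbon and a saturated chain carbon, a 1.7-fold lower number from compound 3 to compound 4 (0.23 log units; within the scatter), does not separate the two compounds, so isopropyl and hydrogen cannot be told apart there in this series. On the saturated chain carbon bound to an aromatic carbon, propyl and 4-methoxyphenyl are likewise not separated, a 2.0-fold lower number from compound 2 to compound 4 (0.30 log units; within the scatter), whereas cyclohexyl stands apart, a 66-fold higher number from compound 1 to compound 4 (1.82 log units; beyond the scatter), which makes compound 1 the only one of the four with a clearly lower number. Nothing at hand explains these differences.

The compounds shown leave open whether isopropyl would be equally silent alongside cyclohexyl. They also leave open whether cyclopentyl or an amine on that chain carbon would match compound 1.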